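Replacing the 4-cyanobenzyl group: an expected solubility

The compounds below may be only part of what the source reports. "The series", "measured", "known", "first", "only" and "open" are said of these compounds alone.

Compound 3 `COc1cccc(CNCCCNc2ccnc3cc(Cc4ccc(C#N)cc4)ccc23)c1O` gives 4200 nM in a physicochemical assay for solubility, with a stated time of 18 h, at pH 7.4 (a higher number here means a more soluble compound, a lower number a less soluble compound), and stands level with compound 2 `COc1ccc(F)cc1CNCCCNc1ccnc2cc(Cc3ccc(C#N)cc3)ccc12` which gives 4200 nM in this assay so that the two share the lowest number of the three. Compound 1 `COc1cccc(CNCCCNc2ccnc3cc(Oc4ccccc4)ccc23)c1O` gives 14500 nM in this assay and the step of a 3.5-fold lower number from compound 1 to compound 3 (0.54 log units; beyond the scatter) is a modest fall, whereas no change at the digits printed from compound 2 to compound 3 (within the scatter) shows no change. Compound 4 `COc1cccc(CNCCCNc2ccnc3cc(-c4ccc(C(C)(C)C)cc4)ccc23)c1O` differs from compound 3 by 4-(tert-butyl)phenyl in place of 4-cyanobenzyl on an aromatic carbon on the same aromatic carbon where the earlier fall occurred. Among the measured compounds shown here, no measured step covers this exchange, so the expectation rests only on that earlier fall and is uncertain. The expected step for compound 4 is a 2.8-fold lower number from compound 3 to compound 4 (0.45 log units; beyond the scatter) in this assay and is modest. The estimate for compound 4 is 1500 nM with a range from 400 nM to 5000 nM in this assay.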

Compound 4, solubility: 32000 nM
Compound 4: the middle estimate sits 21-fold (1.33 log units) below what was measured, and the stated range ends below it.
By their numbers in this assay, from the lowest: compounds 2 and 3 (each within the scatter of the next); then compound 1; then compound 4.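

In this assay, among the compounds shown here, the earlier compounds showed only a fall at this aromatic carbon, whereas 4-(tert-butyl)phenyl reverses the direction: there is a 7.6-fold higher number from compound 3 to compound 4 (0.88 log units; beyond the scatter), and also a 2.2-fold higher number from compound 1 to compound 4 (0.34 log units; beyond the scatter). Of the three groups shown at this place, 4-(tert-butyl)phenyl therefore gives the highest number. Nothing available explains this rise.

On these data alone, whether the rise goes with the tert-butyl group or with the phenyl ring alone stays open. Also open, as far as these compounds go, is how a plain phenyl, or a phenyl carrying an amine or a carboxylic acid, would read here.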